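Cyclohexyl in Place of Chlorophenyl on the Amine

A few compounds are considered here, and "the series" means these few. Any claim that something is new, unique, unknown or untested is made for them only; others in the source may bear on it.

Compound 1 `O=C1C(Nc2cccc(Cl)c2)=CC(=O)c2c1nc1n2[C@H]2OC[C@@H](O)[C@H]2OC1` and compound 2 `O=C1C=C(Nc2ccccc2)C(=O)c2c1nc1n2[C@H]2OC[C@@H](O)[C@H]2OC1` share one core and carry different groups on the amine nitrogen. In a functional assay on ECa-109 cells for inhibition, with ECa-109 cell line (Homo sapiens) as the target, read by sulforhodamine B assay (on this read-out higher numbers stand for weaker inhibition and lower numbers for stronger inhibition), compound 1 gives 3080 nM, and compound 2 gives 4970 nM; these two numbers lie within the usual scatter of each other, so no difference in inhibition can be claimed between them. Compound 3 `O=C1C(NC2CCCCC2)=CC(=O)c2c1nc1n2[C@H]2OC[C@@H](O)[C@H]2OC1` has not yet been measured in this assay. It differs from compound 1 by cyclohexyl in place of 3-chlorophenyl on an amine nitrogen. For the measured compounds named here, no measured pair shows a change of this kind, so its effect is unknown. The expected step of a 1.3-fold higher number from compound 1 to compound 3 (0.11 log units; within the scatter) is small, probably within the scatter. Compound 3 is estimated at 4000 nM, with a range from 1500 nM to 11000 nM.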

Compound 3, half-maximal inhibitory concentration: > 16000 nM
Compound 3 was reported as a limit; the forecaster's own chance of this, stated with the estimate: 10%; middle value at least 4.0-fold (0.60 log units) from the limit.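

In this assay, the change gives an at least 5.1-fold higher number from compound 1 to compound 3 (0.71 log units; beyond the scatter), so the group on this amine nitrogen does matter, something compound 1 and compound 2 could not show. Replacing the 3-chlorophenyl ring with cyclohexyl, a six-membered non-aromatic ring, clearly weakens inhibition. Compound 3 is reported only as a limit, so this step gives a minimum size: the limit of > 16000 nM in this assay, at which 1 of the 3 values shown sits.

From the compounds shown here alone, it remains open whether an aromatic ring itself is what counts here. A pyridine ring or a short chain such as butyl on this nitrogen could help to settle that.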